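The compounds below may be only part of what the source reports. "The series", "measured", "known", "first", "only" and "open" are said of these compounds alone.

Of the compounds shown here, three have been measured in a functional assay on T47D cells (Homo sapiens) for activation; a higher number here means that more compound is needed for the effect, a lower number that less compound is needed. Compound 1 `N#CC1=C(N)Oc2c(ccc(N)c2N)C1c1cccc(C#N)c1` gives 390000000 nM, compound 2 `CCOc1ccc2c(c1)OC(N)=C(C#N)C2c1cc(Br)c(OC)c(OC)c1` gives 64000000 nM, and compound 3 `COc1cncc(C2C(C#N)=C(N)Oc3cc(OC)ccc32)c1` gives 47000000 nM. Compound 2 thus holds the second highest of the three numbers: its value and that of compound 3 lie within the scatter of each other, while compound 1 sits beyond the scatter with a higher number. Compound 4 `COc1cc(C2C(C#N)=C(N)Oc3cc(Br)ccc32)cc(Br)c1OC` is not yet measured and differs from compound 2 in one place: bromo in place of ethoxy on an aromatic carbon. For the measured compounds named here, no pair of measured compounds differing in one place is available to guide this change, so its size in this assay is open; the expectation is a step no larger than the scatter, in no firm direction, giving a 1.1-fold lower number from compound 2 to compound 4 (0.03 log units; within the scatter). Compound 4 is therefore estimated at 60000000 nM, with a range from 15000000 nM to 250000000 nM.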

Compound 4, half-maximal effective concentration: 140000000 nM
The estimate for compound 4 lay 2.3-fold (0.37 log units) below the measured number, and the stated range covers the measured number.
By their numbers in this assay, from the lowest: compounds 3 and 2 (each within the scatter of the next); then compound 4; then compound 1.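

In this assay, for the compounds shown here, bromo in place of ethoxy on an aromatic carbon of the fused system gives a 2.2-fold higher number from compound 2 to compound 4 (0.34 log units; beyond the scatter) and supplies the first comparison of compounds differing in one place. It shows that this position is not indifferent to the change: with bromo there, more compound is needed, by a modest step. Nothing available bears on the reason for this step.

This single step cannot separate the loss of ethoxy from the gain of bromo. As far as these compounds go, how a longer chain such as butoxy, a fluoro or a carboxylic acid would fare at this position remains open.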